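Fluorophenyl isomers: from compound 2 to compound 3

This account rests on a few compounds, and the source may have more. Where it says the series, first, only, none or still open, it means among the compounds named here.

Compound 1 `Cc1ccnnc1N1CCN(c2ncccn2)CC1` sits at the limit of the assay: in a functional assay on BV-2 cells (Mus musculus) for inhibition, read by ELISA, with a stated time of 16 h (a lower number here means a stronger inhibitor, a higher number a weaker inhibitor), compound 1 gives > 100000 nM. For the measured compounds named here, compound 2 `Cc1cc(-c2cccc(F)c2)nnc1N1CCN(c2ncccn2)CC1` gives 33500 nM in this assay, the only actual number. Going by the values given here, the single measured step, an at least 2.9-fold lower number from compound 1 to compound 2 (0.47 log units; beyond the scatter), rests on the limit of > 100000 nM in this assay, at which 1 of the 2 values shown sits, and tells nothing about exchanging one fluorophenyl for another. Compound 3 `Cc1cc(-c2ccc(F)cc2)nnc1N1CCN(c2ncccn2)CC1` differs by 4-fluorophenyl in place of 3-fluorophenyl on an aromatic carbon. Among the compounds with values here, with no step bearing on this swap, compound 3 is expected to stay close to compound 2, an estimated change of a 1.1-fold lower number from compound 2 to compound 3 (0.05 log units; within the scatter). The estimate for compound 3 is 30000 nM, between 10000 nM and 100000 nM.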

Compound 3, half-maximal inhibitory concentration: 76300 nM
For compound 3 the middle estimate is 2.5-fold (0.41 log units) below the measured one, and the stated range covers the measured number.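

In this assay, the two fluorophenyl isomers differ modestly at this position: 4-fluorophenyl in place of 3-fluorophenyl gives a modest step (a 2.3-fold higher number from compound 2 to compound 3 (0.36 log units; beyond the scatter)). The entering and leaving groups have the same atoms, so where the fluorine sits on the phenyl ring alone changes the number. The other step (an at least 1.3-fold lower number from compound 1 to compound 3 (0.11 log units; that floor lies within the scatter)) cannot be read as a gain, because its floor lies within the scatter and it rests on a limit: the limit of > 100000 nM in this assay, at which 1 of the 3 values shown sits.

Open, going by these compounds, is how a plain phenyl, a methoxyphenyl or a morpholine at this carbon would compare with compound 2 and compound 3.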